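The source may hold more compounds than are shown below. What is called first, only, known or untested is meant among the compounds shown, and "the series" means these compounds.

Of the compounds shown here, three have so far been measured in a functional assay on HCT-116 cells (Homo sapiens) for inhibition, read by sulforhodamine B assay, with a stated time of 48 h, tested at 50 uM (a lower number here means less inhibition of growth, a higher number more inhibition of growth at the concentration tested), and a fourth is waiting for its number. Compound 1 `COc1ccc(/C=C/C(=O)/C=C/c2ccc(OCc3cn(CCCCOc4cc(=O)oc5ccccc45)nn3)c(OC)c2)cc1OC` gives 55% in this assay. Compound 2 `COc1cc(/C=C/C(=O)/C=C/c2ccccc2)ccc1OCc1cn(CCCCOc2cc(=O)oc3ccccc23)nn1` gives 34%. The only difference between the two is phenyl in place of 3,4-dimethoxyphenyl on a double-bonded chain carbon bound to a double-bonded chain carbon, and this change produced a number 21 percentage points lower from compound 1 to compound 2 (beyond the scatter). Compound 3 `COc1ccc(/C=C/C(=O)/C=C/c2ccc(OCc3cn(CCOc4cc(=O)oc5ccccc45)nn3)c(OC)c2)cc1OC` gives 82%, the highest of the three, and its steps to compound 1 and to compound 2 both lie beyond the scatter. How the core of compound 3 differs from the core of compound 1 is not broken down here.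

Compound 4 `COc1cc(/C=C/C(=O)/C=C/c2ccccc2)ccc1OCc1cn(CCOc2cc(=O)oc3ccccc23)nn1` has not yet been measured. It differs from compound 3 by phenyl in place of 3,4-dimethoxyphenyl on a double-bonded chain carbon bound to a double-bonded chain carbon. The place of this change reads the same, word for word, as in the pair of compound 1 and compound 2, so it is the same change seen a second time, occurring twice in all among these compounds. Because the same change earlier gave a number 21 percentage points lower from compound 1 to compound 2 (beyond the scatter), a loss of similar size is expected here, namely a number 22 percentage points lower from compound 3 to compound 4 (beyond the scatter) in this assay. Within the data shown here, only one earlier example of the change exists, so the expectation rests on a single step and on the assumption that the change behaves alike on the core of compound 3. Compound 4 is therefore estimated at 60%, most likely between 45% and 75%.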

Compound 4, percent growth inhibition at one concentration: 56%
Estimate against measurement, compound 4: 4 percentage points above; low and high end bracket the measured number.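

In this assay, putting phenyl in place of 3,4-dimethoxyphenyl gives a number 26 percentage points lower from compound 3 to compound 4 (beyond the scatter), so the change that lowered growth inhibition on the core of compound 1 also lowers it on the core of compound 3. The size of the loss carries over as well, and the two steps cannot be told apart: the same change on two cores in this assay, a number 21 percentage points lower (beyond the scatter) from compound 1 to compound 2 and a number 26 percentage points lower (beyond the scatter) from compound 3 to compound 4, 5 percentage points apart, within the scatter of two such steps This supports treating the change as roughly additive in this small set, meaning that its effect can be added to the value of a new core, but two cores are a thin basis, and the result neither explains why the 3,4-dimethoxyphenyl group gives more inhibition nor shows that the same would hold on any other core.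

The compounds shown leave open what other groups would do at this place, for example a phenyl ring carrying an amine or a carboxylic acid, or a phenyl ring carrying only one methoxy group. They also leave open whether the step would keep its size on a core with a longer chain, and whether it would hold at other concentrations or in other cell lines.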